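This account rests on a few compounds, and the source may have more. Where it says the series, first, only, none or still open, it means among the compounds named here.

Compound 1 `Cc1ccccc1Cn1ccc2nc(-c3ccccc3)nc-2c1` is the reference point of this small series. In an ADME assay on MDBK cells (Bos taurus) for cytotoxicity (on this read-out higher numbers stand for lower toxicity in this test and lower numbers for higher toxicity in this test), compound 1 gives only a limit, > 100000 nM. Compound 2 `COc1ccccc1Cn1ccc2nc(-c3ccccc3)nc-2c1` likewise gives only a limit in this assay, > 100000 nM. Compound 3 `Fc1cccc(Cn2ccc3nc(-c4ccccc4)nc-3c2)c1` also gives only a limit in this assay, > 100000 nM. The steps a step that the two limits leave unreadable from compound 1 to compound 2, a step that the two limits leave unreadable from compound 1 to compound 3 and a step that the two limits leave unreadable from compound 2 to compound 3 are therefore of unreadable size; all three compounds share (the limit of > 100000 nM in this assay, at which 3 of the 3 values shown sit). Compound 4 `Brc1ccccc1Cn1ccc2nc(-c3ccccc3)nc-2c1` differs from compound 1 by bromo in place of methyl on an aromatic carbon. Among the measured compounds shown here, no measured step bears on this change beyond the three unreadable ones, so no step beyond the scatter is expected in this assay. Compound 4 is therefore expected to give 150000 nM, between 50000 nM and 500000 nM, most likely again reported as a limit. That expectation corresponds to a step that the limit leaves unreadable from compound 1 to compound 4.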

Compound 4, half-maximal cytotoxic concentration: > 100000 nM
Compound 4: only a limit was reported (the forecaster's own chance of this, stated with the estimate: 85%); the middle value is on the limit's open side.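

Compound 4 gives only a limit, so no step from compound 1, compound 2 or compound 3 to compound 4 can be read: the limit of > 100000 nM in this assay, at which 4 of the 4 values shown sit.

The compounds shown leave open what size, if any, the steps among these four compounds have in this assay.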